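Bromo-to-methyl swap across two enone cores

The compounds below may be only part of what the source reports. "The series", "measured", "known", "first", "only" and "open" are said of these compounds alone.

Measured so far, in a functional assay on MOLT-4 cells (Homo sapiens) for inhibition; a lower number here means a stronger inhibitor, a higher number a weaker inhibitor:
compound 1 `O=C1/C(=C/c2cccc(Br)c2)CCCc2ccccc21`: 17100 nM
compound 2 `Cc1cccc(/C=C2\CCCc3ccccc3C2=O)c1`: 34600 nM
compound 3 `O=C1CCCCC/C1=C\c1ccc(Br)cc1`: 49400 nM

Compound 1 and compound 2 share one core and differ only at the aromatic ring, where (methyl in place of bromo on an aromatic carbon). That change gave a 2.0-fold higher number from compound 1 to compound 2 (0.31 log units; beyond the scatter) in this assay. Compound 3 carries a different core; the difference between the two cores is not broken down here. Compound 3 shows the highest number of the three, but its value and that of compound 2 lie within the scatter of each other, while its gap to compound 1 is beyond it.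

Compound 4 `Cc1ccc(/C=C2\CCCCCC2=O)cc1` is not yet measured. Relative to compound 3, (methyl in place of bromo on an aromatic carbon). This is the same kind of change as from compound 1 to compound 2, though the surroundings differ: there the methyl sits meta to a large group, here para to a group of 9 heavy atoms. Within the data shown here, only one earlier instance exists, so the expectation rests on a single step.

For compound 4 in this assay the expected step is a 1.9-fold higher number from compound 3 to compound 4 (0.28 log units; within the scatter), because the same kind of change gave a 2.0-fold higher number from compound 1 to compound 2 (0.31 log units; beyond the scatter). Compound 4 is therefore estimated at 95000 nM, with a range from 40000 nM to 220000 nM.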

Compound 4, half-maximal inhibitory concentration: > 500000 nM
Compound 4: no number, only a limit; the forecaster's own chance of this, stated with the estimate: 25%; middle value at least 5.2-fold (0.72 log units) from the limit.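

In this assay compound 4 gives > 500000 nM, which is a limit of the assay and not a number. Methyl in place of bromo on an aromatic carbon gives an at least 10-fold higher number from compound 3 to compound 4 (1.00 log units; beyond the scatter), so the change keeps its direction on the second core but its size does not carry over from the first: the same change on two cores in this assay, a 2.0-fold higher number (0.31 log units; beyond the scatter) from compound 1 to compound 2 and an at least 10-fold higher number (1.00 log units; beyond the scatter) from compound 3 to compound 4, at least 5.0-fold (0.69 log units) apart, beyond the scatter of two such steps

This does not show that the core alone sets the size of the step, as there is only one pair per core and the two pairs also differ in where the group sits on the aromatic ring, and the full size of the step on the core of compound 3 stays unknown: the limit of > 500000 nM in this assay, at which 1 of the 4 values shown sits.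

Open, going by these compounds, is how a chloro, a methoxy or a dimethylamino group in the same place would read on either core, and so whether bromo is unusual among such groups or methyl is. Also open, on these data alone, is whether the two cores would still part if bromo and methyl sat at the same place on the aromatic ring in both.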